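The compounds below may be only part of what the source reports. "The series", "measured", "known", "first", "only" and "open" are said of these compounds alone.

Measured so far in a functional assay on RAW264.7 cells (Mus musculus) for inhibition, read by ELISA, with a stated time of 24 h; on this read-out lower numbers stand for an effect already at smaller amounts and higher numbers for an effect only at larger amounts of compound:
- compound 1 `CC/C=C\C[C@H]1C(=O)C=C[C@H]1CC(=O)OCCC` gives 23000 nM
- compound 2 `CC/C=C\C[C@H]1C(=O)C=C[C@H]1CC(=O)Oc1ccc(O)cc1` gives 23000 nM
- compound 3 `CC/C=C\C[C@H]1C(=O)C=C[C@H]1CC(=O)OCCOCCOC` gives 33000 nM

All three share the core of compound 1 and differ only in the group on the oxygen next to a carbonyl group: propyl, 4-hydroxyphenyl or 2-(2-methoxyethoxy)ethyl. Compound 3, at 33000 nM, stands within the scatter of both other compounds, so the three values form a single level.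

Next in the series is compound 4 `CC/C=C\C[C@H]1C(=O)C=C[C@H]1CC(=O)OC(C)CC`, which carries sec-butyl in place of 2-(2-methoxyethoxy)ethyl on that same oxygen: sec-butyl in place of 2-(2-methoxyethoxy)ethyl on an oxygen next to a carbonyl group.

The bearing evidence is the three measured exchanges at this place, which gave no change at the digits printed from compound 1 to compound 2 (within the scatter), a 1.4-fold higher number from compound 1 to compound 3 (0.16 log units; within the scatter) and a 1.4-fold higher number from compound 2 to compound 3 (0.16 log units; within the scatter). The closest of these is the second, since compound 1 also carries a saturated chain there. Among the measured compounds shown here, no measured compound carries a branched group at this place, so the range is kept wider than the measured spread.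

The expected change in this assay is none beyond the scatter, with an estimated 1.3-fold lower number from compound 3 to compound 4 (0.12 log units; within the scatter).

The estimate for compound 4 is 25000 nM, with an expected range of 13000 nM to 45000 nM.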

Compound 4, half-maximal effective concentration: 22000 nM
Estimate against measurement, compound 4: 1.1-fold (0.06 log units) above, within the range that was stated.
By their numbers in this assay, from the lowest: compounds 4, 1, 2 and 3 (each within the scatter of the next).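

In this assay, among the compounds shown here, sec-butyl brings the first branched group to this place, and the added methyl on the saturated chain carbon bound to the oxygen leaves the reading within the scatter, with a 1.0-fold lower number from compound 1 to compound 4 (0.02 log units; within the scatter) as the closest comparison. The other two exchanges, a 1.0-fold lower number from compound 2 to compound 4 (0.02 log units; within the scatter) and a 1.5-fold lower number from compound 3 to compound 4 (0.18 log units; within the scatter), also stay within the scatter, the second even though 2-(2-methoxyethoxy)ethyl with 7 heavy atoms and 2 hydrogen-bond acceptors gives way to sec-butyl with 4 heavy atoms and 0 hydrogen-bond acceptors. Propyl, sec-butyl, 4-hydroxyphenyl and 2-(2-methoxyethoxy)ethyl on this oxygen therefore form a single level, and none of the four compounds goes against it, though no measurement on hand gives a reason for this flat picture.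

Going by these compounds, whether an amine or a carboxylic acid carried on this oxygen would stay at the same level remains open. The compounds shown also leave open whether any group at this place moves the number beyond the scatter, and what an exchange elsewhere on the shared core would do.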